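Piperazine thiosemicarbazones: ring hydroxylation of compound 1

This account rests on a few compounds, and the source may have more. Where it says the series, first, only, none or still open, it means among the compounds named here.

Working notes on a small series tested in a functional assay on HBL-100 cells (Homo sapiens) for antiproliferative activity, read by MTT assay, with a stated time of 72 h; on this read-out lower numbers stand for stronger inhibition and higher numbers for weaker inhibition. Three compounds carry numbers. Compound 1 `S=C(N/N=C/c1ccccc1)N1CCNCC1` gives 2410 nM in this assay, the highest of the three; its nearest neighbour, compound 2 `S=C(NN=C(c1ccccc1)c1ccccc1)N1CCNCC1`, gives 340 nM, a lower number beyond the scatter, and compound 3 `C/C(=N/NC(=S)N1CCNCC1)c1ccccc1`, the furthest, gives 290 nM, also beyond the scatter. Among the compounds with values here, compounds 2 and 3 differ from compound 1 at a site other than the aromatic ring, so their numbers say nothing direct about a change on that ring; no pair measured so far differs in one place.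

The untested compound 4 `Oc1ccc(/C=N/NC(=S)N2CCNCC2)cc1` departs from compound 1 by hydroxy in place of hydrogen on an aromatic carbon. The hydroxy enters on an aromatic carbon of a six-membered aromatic ring of carbon only, para to a large group. Within the data shown here, with no comparable step in hand, a small shift toward a lower number is expected, of a size that may not clear the scatter: the step from compound 1 to compound 4 is estimated at a 1.6-fold lower number from compound 1 to compound 4 (0.21 log units; within the scatter). On that basis compound 4 is expected to give about 1500 nM in this assay, within a range from 500 nM to 4500 nM.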

Compound 4, half-maximal inhibitory concentration: 180 nM
Estimate against measurement, compound 4: 8.3-fold (0.92 log units) above; the whole stated range lies above it.
By their numbers in this assay, from the lowest: compounds 4, 3 and 2 (each within the scatter of the next); then compound 1.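

In this assay, within the data shown here, the replacement of hydrogen by hydroxy on an aromatic carbon, para to a large group, gives a 13-fold lower number from compound 1 to compound 4 (1.13 log units; beyond the scatter) and provides the first step that can be read at a single site. The aromatic ring of compound 1 is thereby shown to be a place where this one change, adding a single oxygen as the only new heavy atom, moves the number by a large step beyond the scatter, which compound 2 and compound 3, altered at another site, could not show. Nothing on hand bears on why the step is this large, so it stands as an observation on this one pair.

One open question is whether the step belongs to hydroxy specifically or would also appear with another group on the same aromatic carbon, such as methoxy, an amine or fluorine. Among these compounds, the single pair also leaves open whether hydroxy gives a similar step on other carbons of the ring, or on the aromatic rings of compound 2 and compound 3.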